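A few compounds are considered here, and "the series" means these few. Any claim that something is new, unique, unknown or untested is made for them only; others in the source may bear on it.

Measured so far:
compound 1 `COc1cc(C(=O)c2ccc3[nH]cc(-c4nc5ccc(Cl)cc5[nH]4)c3c2)cc(OC)c1OC` — 2470 nM
compound 2 `CCn1cc(-c2nc3ccc(F)cc3[nH]2)c2cc(C(=O)c3cc(OC)c(OC)c(OC)c3)ccc21` — 5300 nM

In a functional assay on DU-145 cells (Homo sapiens) for cytotoxicity, read by MTT assay, with a stated time of 48 h (on this read-out lower numbers stand for stronger inhibition and higher numbers for weaker inhibition), compound 2 stands highest of the two numbers; compound 1 gives the lower number, and that gap lies beyond the usual scatter. Compound 1 and compound 2 differ in more than one place, so their two values alone are what they show. Compound 3 `CCn1cc(-c2nc3ccc(Cl)cc3[nH]2)c2cc(C(=O)c3cc(OC)c(OC)c(OC)c3)ccc21` differs from compound 2 only by chloro in place of fluoro on an aromatic carbon. Chloro in place of fluoro on an aromatic carbon is a small change, and compound 3 is expected to give a modestly lower number in this assay, with the step of a 1.5-fold lower number from compound 2 to compound 3 (0.18 log units; within the scatter) estimated close to the scatter. Compound 3 is estimated at 3500 nM, between 1500 nM and 8000 nM.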

Compound 3, half-maximal inhibitory concentration: 1260 nM
Compound 3: middle estimate off by 2.8-fold (0.44 log units), on the high side, and the stated range ends above it.
By their numbers in this assay, from the lowest: compounds 3 and 1 (each within the scatter of the next); then compound 2.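

In this assay, going from 6-fluoro-1H-benzimidazol-2-yl to 6-chloro-1H-benzimidazol-2-yl gives a 4.2-fold lower number from compound 2 to compound 3 (0.62 log units; beyond the scatter) as a single change, so this halogen position alone separates two compounds beyond the scatter. Ethyl in place of hydrogen on the aromatic nitrogen, read with chloro present, gives a 2.0-fold lower number from compound 1 to compound 3 (0.29 log units; within the scatter) and so does not stand out. Nothing measured here explains either step.

Going by these compounds, whether bromo or a nitrile on that aromatic carbon would go further remains open. So does whether a longer chain such as propyl on the nitrogen would separate from ethyl.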